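The source may report more compounds than this note shows. Statements on the series, on what has been measured and on what is new or still open speak of the compounds shown alone.

Measured so far:
Compound 1, `COc1ccc(CNc2nc3cc(N)cc(N)c3nc2-c2ccccc2)cc1OC`: in a functional assay on OVCAR-5 cells (Homo sapiens) for inhibition, read by sulforhodamine B assay, with a stated time of 48 h (on this read-out higher numbers stand for lower toxicity in this test and lower numbers for higher toxicity in this test), compound 1 gives 81300 nM.
Compound 2, `Nc1cc(N)c2nc(-c3ccccc3)c(NCc3ccc(F)cc3)nc2c1`: in this assay compound 2 gives only a limit of the test, < 100000 nM.

Compound 2 therefore stands at a limit and not at a number; where it sits beneath that limit is not known. For the measured compounds named here, the one measured step, a step that the limit leaves unreadable from compound 1 to compound 2, cannot be sized for the same reason, as the limit of < 100000 nM in this assay, at which 1 of the 2 values shown sits, shows. Compound 3, `Nc1cc(N)c2nc(-c3ccccc3)c(Oc3ccc(F)cc3)nc2c1`, is the next compound to be measured. It differs from compound 2 by 4-fluorophenoxy in place of (4-fluorobenzyl)amino on an aromatic carbon. No measured step covers an exchange of this kind, so nothing in the numbers shown points to a direction or a size for the change from compound 2 to compound 3. Going by the values given here, both compounds already measured sit in a region of weak toxicity, compound 1 with a number and compound 2 with a limit, and that region is the only guide available. Compound 3 is therefore expected to give 70000 nM, with a range from 25000 nM to 150000 nM. The step this estimate means is a step that the limit leaves unreadable from compound 2 to compound 3, within the scatter of repeated measurements.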

Compound 3, concentration lethal to 50% of the cells: < 100000 nM
Compound 3: only a limit was reported (the forecaster's own chance of this, stated with the estimate: 40%); the middle value is on the limit's open side.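

Compound 2 and compound 3 both stand at a limit of the test and not at a number, so no size can be read for the exchange of (4-fluorobenzyl)amino for 4-fluorophenoxy: the limit of < 100000 nM in this assay, at which 2 of the 3 values shown sit. The compounds shown leave open where compound 2 and compound 3 really sit in this assay, and whether this exchange changes the result at all.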